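The source may report more compounds than this note shows. Statements on the series, on what has been measured and on what is new or still open speak of the compounds shown alone.

Working notes on the series.

Compound 1 `Cc1ccc(C(=O)NC(N)=O)cc1NC(=O)C(C)Br` and compound 2 `Cc1ccc(C(=O)NC(N)=O)cc1NC(=O)C(C)Cl` share one core and differ in a single place: chloro in place of bromo on a saturated chain carbon bound to a carbonyl carbon and a saturated chain carbon. In a functional assay on CCRF-CEM cells (Homo sapiens) for antiproliferative activity, read by trypan blue exclusion, with a stated time of 72 h (a higher number here means a weaker inhibitor, a lower number a stronger inhibitor), compound 1 gives 3360 nM. For compound 2 this assay returns no number but a limit, > 20000 nM. The step of an at least 5.9-fold higher number from compound 1 to compound 2 (0.77 log units; beyond the scatter) is therefore a bound rather than a settled size, because it rests on (the limit of > 20000 nM in this assay, at which 1 of the 3 values shown sits).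

Compound 3 `NC(=O)NC(=O)c1ccc(NC(=O)CBr)o1` sits on a different core; the difference between the two cores is not broken down here. In this assay compound 3 gives 4050 nM, which lies within the scatter of compound 1.

Compound 4 `NC(=O)NC(=O)c1ccc(NC(=O)CCl)o1` has not yet been measured. It stands to compound 3 as compound 2 stands to compound 1: chloro in place of bromo on a saturated chain carbon bound to a carbonyl carbon. The place is not word for word the same: in compound 3 the carbon carrying the halogen is bound to a carbonyl carbon only, while in compound 1 it is bound to a carbonyl carbon and a saturated chain carbon, so this is the same kind of change, not the same change.

The step expected is a 6.2-fold higher number from compound 3 to compound 4 (0.79 log units; beyond the scatter), to be read beside the measured at least 5.9-fold higher number from compound 1 to compound 2 (0.77 log units; beyond the scatter), and it rests on that step and on the value of compound 3, 4050 nM. Compound 4 is accordingly estimated at 25000 nM, with an expected range from 8000 nM to 80000 nM. A limit rather than a number is a fair possibility for compound 4, given (the limit of > 20000 nM in this assay, at which 1 of the 3 values shown sits).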

Compound 4, half-maximal inhibitory concentration: 16600 nM
Compound 4: the middle estimate sits 1.5-fold (0.18 log units) above what was measured, within the range that was stated.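

In this assay, chloro in place of bromo on the core of compound 3 gives a 4.1-fold higher number from compound 3 to compound 4 (0.61 log units; beyond the scatter), a step of settled size. The change moves the number the same way in both pairs, but whether the size of the step carries over from one core to the other stays unsettled: the same change on two cores in this assay, an at least 5.9-fold higher number (0.77 log units; beyond the scatter) from compound 1 to compound 2 and a 4.1-fold higher number (0.61 log units; beyond the scatter) from compound 3 to compound 4; the limit leaves it open whether they differ. This is a reading of two pairs only, and the place is not word for word the same, as the carbon carrying the halogen in compound 1 is also bound to a saturated chain carbon, so the direction is shared by these pairs but no general rule for the series is shown.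

The compounds shown leave open how iodo, or a plain hydrogen in place of the halogen, would read on either core, and what a longer chain on the carbon carrying the halogen would do. They also do not separate the contribution of the core from that of the saturated chain carbon, as compound 1 and compound 3 differ in both.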